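The source may report more compounds than this note shows. Statements on the series, on what has been measured and on what is new or still open speak of the compounds shown alone.

Measured so far in a functional assay on UMUC3 cells (Homo sapiens) for antiproliferative activity, read by MTT assay, with a stated time of 72 h; on this read-out lower numbers stand for stronger inhibition and higher numbers for weaker inhibition:

- compound 1 `CC(C)CNC(=N)NC(=N)Nc1ccc(F)cc1F`: 17300 nM
- compound 2 `CC(C)NC(=N)NC(=N)Nc1ccc(C(F)(F)F)cc1`: 5200 nM
- compound 3 `CCCCCCCNC(=N)NC(=N)Nc1ccc(F)c(F)c1`: 2100 nM

Compound 1 has the highest number of the three, so it is the weakest inhibitor measured here. Its gaps to the other two both lie beyond the usual scatter of repeated measurements, with compound 2 the nearer and compound 3 the further. However, compound 2 and compound 3 each differ from compound 1 in more than one place, so their values cannot show what any single change does.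

The next compound to be tested is compound 4 `N=C(NC(=N)NC1CCCC1)Nc1ccc(F)cc1F`. It keeps the rest of compound 1 and makes one change, cyclopentyl in place of isobutyl on an amine nitrogen.

Among the compounds with values here, no measured pair isolates this swap, so the expectation is loose. Compound 1 gives 17300 nM, compound 2 gives 5200 nM and compound 3 gives 2100 nM, which leaves more room for a fall than a rise. A modest move toward stronger inhibition in this assay is therefore expected, and it may not clear the scatter. The expected change is a 1.9-fold lower number from compound 1 to compound 4 (0.28 log units; within the scatter). For compound 4 the estimated value is 9000 nM, with an expected range of 3500 nM to 20000 nM.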

Compound 4, half-maximal inhibitory concentration: 18400 nM
Compound 4: middle estimate off by 2.0-fold (0.31 log units), on the low side; measured number inside the range.
By their numbers in this assay, from the lowest: compound 3; then compound 2; then compounds 1 and 4 (each within the scatter of the next).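

Within the data shown here, replacing isobutyl with cyclopentyl on this amine nitrogen gives a 1.1-fold higher number from compound 1 to compound 4 (0.03 log units; within the scatter) in this assay, the first comparison here that isolates one change. At this position, then, going from a branched chain of 4 carbon atoms to a five-membered ring of 5 carbon atoms produces no readable difference in antiproliferative activity, so compound 1 and compound 4 cannot be ranked against each other. Nothing measured on these compounds offers an explanation for this result.

On these data alone, what remains open is whether this insensitivity extends to other groups on the same nitrogen, such as a cyclohexyl ring or a benzyl group, or holds only for these two groups of similar size in atom count. No pair shown changes the fluorine substitution alone or the nitrogen substituent on a different fluorine pattern, so the lower numbers of compound 2 and compound 3 cannot yet be traced to either part of the molecule.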